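The compounds below may be only part of what the source reports. "The series", "measured", "known", "first", "only" and "open" are said of these compounds alone.

Measured compounds and their numbers:
Compound 1, `O=C(O)COc1ccc(/C=C/C(=O)c2ccc(Cl)c(Cl)c2)cc1`, a functional assay on MCF7 cells (Homo sapiens) for inhibition; a higher number here means a weaker inhibitor, a lower number a stronger inhibitor: 15000 nM
Compound 2, `O=C(/C=C/c1ccc(I)cc1)c1ccc(O)cc1`: 7000 nM
Compound 3, `O=C(/C=C/c1ccc(B(O)O)cc1)c1ccc(Cl)c(Cl)c1`: 5500 nM

Compound 2 sits close to compound 3, the two numbers lying within the usual scatter of each other, while compound 1 stands clearly higher, so compound 2 is one of the two stronger inhibitors among the three. Compound 4, `O=C(/C=C/c1ccc(I)cc1)c1ccc(OCB(O)O)cc1`, is compound 2 with a change on the phenol side: a group of 4 heavy atoms (1 carbon, 1 boron, 2 oxygen; no ring) in place of a hydrogen atom, on an oxygen on an aromatic ring. Among the compounds with values here, only one measured step involves a boron-bearing group, and it is a 2.7-fold lower number from compound 1 to compound 3 (0.44 log units; beyond the scatter). That step swapped one group for another on an aromatic carbon of the other ring, whereas here a group is attached to an oxygen that previously carried only hydrogen, so the two situations resemble each other only loosely. Nothing measured shows what adding a group to this oxygen does. The expectation is therefore a small shift at most, not clearly beyond the scatter, leaning slightly toward a lower number. Compound 4 is estimated at 5000 nM, within a range of 2000 nM to 15000 nM, which means an expected step of a 1.4-fold lower number from compound 2 to compound 4 (0.15 log units; within the scatter).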

Compound 4, half-maximal inhibitory concentration: 9500 nM
For compound 4 the middle estimate is 1.9-fold (0.28 log units) below the measured one, within the range that was stated.
By their numbers in this assay, from the lowest: compounds 3, 2, 4 and 1 (each within the scatter of the next, the first and the last beyond it).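

Within the data shown here, this is the first view of what happens at the oxygen on the aromatic ring of compound 2: in this assay, a group of 4 heavy atoms (1 carbon, 1 boron, 2 oxygen) in place of the hydrogen atom gives a 1.4-fold higher number from compound 2 to compound 4 (0.13 log units; within the scatter), so the numbers for the two compounds cannot be told apart. The oxygen can therefore carry this group with no step beyond the scatter, and a boron-bearing group does not bring a lower number in every setting: compound 4 stands against the earlier step of a 2.7-fold lower number from compound 1 to compound 3 (0.44 log units; beyond the scatter), where a different group was replaced on an aromatic carbon. No supporting measurement bears on this result.

The compounds shown leave open whether a simple methyl group or a longer chain ending in an amine on this oxygen would give a step beyond the scatter. They also leave open whether the boron itself matters here, which a plain ethyl group on the same oxygen could help to settle.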